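The source may hold more compounds than are shown below. What is called first, only, known or untested is meant among the compounds shown, and "the series" means these compounds.

Measured compounds in a functional assay, with a stated time of 150 min, tested at 15 ug/mL; on this read-out lower numbers stand for a weaker effect and higher numbers for a stronger effect at the one concentration tested:
- compound 1, `COC(=O)c1c(Nc2ccccc2)sc(C(=O)c2ccc(OC)cc2)c1C`, gives 28.6%
- compound 2, `COC(=O)c1c(Nc2ccc(C)cc2)sc(C(=O)c2ccc(OC)cc2)c1C`, is reported as "not active" (no number reported) with no number
- compound 3, `COC(=O)c1c(Nc2ccccc2)sc(C(=O)c2ccc(C)cc2)c1C`, gives 4.59%

Compound 3 holds the lowest of the two numbers in this assay. Within the data shown here, its nearest neighbour is compound 1, and the single change between them, methyl in place of methoxy on an aromatic carbon, gives a number 24 percentage points lower from compound 1 to compound 3 (beyond the scatter).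

Compound 4, `COC(=O)c1c(Nc2ccc(C)cc2)sc(C(=O)c2ccc(C)cc2)c1C`, has not yet been tested. It differs from compound 3 in one place: methyl in place of hydrogen on an aromatic carbon. Among the measured compounds shown here, no step for this exact change has been measured from a numbered value. The closest comparison is the pair compound 1 and compound 2, which differ in the same way; compound 1 gives a number while compound 2 was reported as not active without a number, so their values point towards a weaker effect, though no size can be given.

Compound 3 already sits near the bottom of this assay, so there is little room for a further fall. Compound 4 is therefore expected to stay low, with an estimated change of a number 2.6 percentage points lower from compound 3 to compound 4 (within the scatter), and an estimated value of 2% within a range of 0% to 10%.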

Compound 4, a percentage reported as activity, at one concentration (the size of the read-out at that concentration, not a potency): "not active" (no number reported)
Compound 4 has no reported number here; no gap can be computed for the estimate.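

In this assay compound 4 is reported as not active, without a number, so the step from compound 3 to compound 4 cannot be read. The compounds shown leave open how large the effect of this added methyl is, and no measurement here offers an explanation.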